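Para substituent swap on the aryl of the shared core

A few compounds are considered here, and "the series" means these few. Any claim that something is new, unique, unknown or untested is made for them only; others in the source may bear on it.

Within the data shown here, compound 2 `CCCC(C)n1c(CC)nc2c(-c3ccc(Cl)cc3Cl)ccnc21` gives 0.5 nM in an assay for binding affinity to Corticotropin releasing factor receptor (Rattus norvegicus) (a higher number here means a weaker inhibitor, a lower number a stronger inhibitor), the lowest of the two numbers so far; compound 1 `CCCC(C)n1c(CC)nc2c(-c3ccc(C(F)(F)F)cc3Cl)ccnc21` gives 1.1 nM. Among the measured compounds shown here, the one known step, a 2.2-fold lower number from compound 1 to compound 2 (0.34 log units; beyond the scatter), concerns a different exchange at the same carbon, so no measured step bears directly on the change to compound 3 `CCCC(C)n1c(CC)nc2c(-c3ccc(C(C)O)cc3Cl)ccnc21`: 1-hydroxyethyl in place of chloro on an aromatic carbon. With no guide from the data, the expectation is a weakening step, a 6.0-fold higher number from compound 2 to compound 3 (0.78 log units; beyond the scatter), beyond the scatter. Compound 3 is therefore estimated at 3 nM, within 0.8 nM to 12 nM.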

Compound 3, inhibition constant: 5.1 nM
Compound 3: the middle estimate sits 1.7-fold (0.23 log units) below what was measured; low and high end bracket the measured number.
By their numbers in this assay, from the lowest: compound 2; then compound 1; then compound 3.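

In this assay, this aromatic carbon still tolerates 1-hydroxyethyl, but with a clear penalty: a 10-fold higher number from compound 2 to compound 3 (1.01 log units; beyond the scatter), and a 4.6-fold higher number from compound 1 to compound 3 (0.67 log units; beyond the scatter). Of the three groups shown here, chloro gives the lowest number and 1-hydroxyethyl the highest, and the exchange from chloro is the first large step in the series. Nothing measured here accounts for this loss.

The compounds shown do not tell whether the loss goes with the hydroxyl or with the carbon chain. An ethyl group at this carbon would separate the two, and an amine would test another hydrogen-bond donor there.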